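The source may report more compounds than this note shows. Statements on the series, on what has been measured and on what is new or still open speak of the compounds shown alone.

Compound 1 `N#Cc1ncc2nc1OCC/C=C\COc1ccc(Br)cc1NC(=O)N2`: > 10000 nM
Compound 2 `Cc1ccc2c(c1)NC(=O)Nc1cnc(C#N)c(n1)OCC/C=C\CO2`: > 10000 nM
Compound 3 `N#Cc1ncc2nc1OCC/C=C\COc1ccc(CCOC3CCCCO3)cc1NC(=O)N2`: > 10000 nM

In a functional assay on NCI-H1299 cells (Homo sapiens), read by flow cytometry (on this read-out lower numbers stand for an effect already at smaller amounts and higher numbers for an effect only at larger amounts of compound), compound 3 gives > 10000 nM, which is a limit of the assay and not a number. Compound 3 has no exact place among the three compounds, and the same holds for the others: the limit of > 10000 nM in this assay, at which 3 of the 3 values shown sit.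

Compound 4 `N#Cc1ncc2nc1OCC/C=C\COc1ccc(CCCOC3CCCCO3)cc1NC(=O)N2` differs from compound 3 in one place: ((oxan-2-yl)oxy)methyl in place of (oxan-2-yl)oxy on a saturated chain carbon, two bonds along the chain from an aromatic carbon. Here ((oxan-2-yl)oxy)methyl stands in place of (oxan-2-yl)oxy on a saturated chain carbon, two bonds along the chain from an aromatic carbon. Read one bond further out, 2-((oxan-2-yl)oxy)ethyl becomes 3-((oxan-2-yl)oxy)propyl.

For the measured compounds named here, three measured steps bear on this change: a step that the two limits leave unreadable from compound 2 to compound 3, a step that the two limits leave unreadable from compound 1 to compound 3 and a step that the two limits leave unreadable from compound 1 to compound 2. None of them has a size that can be read. The closest is the step that adds the ((oxan-2-yl)oxy)methyl group, and because a step that the two limits leave unreadable from compound 2 to compound 3 gives no size to carry over, no step beyond the usual scatter is expected in this assay, in either direction.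

The expected outcome is a number no higher from compound 3 to compound 4 (the limit leaves the size open), and this is only an estimate. Compound 4 is estimated at 10000 nM, with an expected range from 3000 nM to 20000 nM.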

Compound 4, half-maximal effective concentration: > 10000 nM
Compound 4 was reported as a limit; the forecaster's own chance of this, stated with the estimate: 80%; the middle value sits exactly at the limit.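

In this assay compound 4 gives > 10000 nM as a limit of the assay and not a number. For the compounds shown here, no step among compound 1, compound 2, compound 3 and compound 4 can be read, because all four stand at the same limit: the limit of > 10000 nM in this assay, at which 4 of the 4 values shown sit.

The compounds shown leave open how far apart these four truly lie, and whether any change to the shared core gives a measurable value.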